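The source may hold more compounds than are shown below. What is called first, only, known or untested is meant among the compounds shown, and "the series" means these compounds.

Compound 2 `ClCc1ccccc1Cn1cnc2c(Cl)ncnc21` gives 61700 nM in a functional assay on T47D cells (Homo sapiens) for cytotoxicity, read by sulforhodamine B assay, with a stated time of 48 h (a higher number here means a weaker inhibitor of growth, a lower number a stronger inhibitor of growth), the highest of the three numbers seen; compound 1 `ClCc1ccccc1Cn1cnc2c(Cl)nc(Cl)nc21` gives 5490 nM and compound 3 `ClCc1ccccc1Cn1cnc2ncnc(Cl)c21` gives 4260 nM. Among the measured compounds shown here, the only single-point step among the measured compounds, an 11-fold higher number from compound 1 to compound 2 (1.05 log units; beyond the scatter), is large. Compound 4 `Nc1nc(Cl)c2ncn(Cc3ccccc3CCl)c2n1` differs from compound 2 by amino in place of hydrogen on an aromatic carbon. For the measured compounds named here, only the step from compound 1 to compound 2 bears on this change; it shows that a substituent at this carbon can shift this assay a long way, but amino is not chloro, so only part of that shift is expected here, downward. Compound 4 is expected at about 15000 nM, with a range of 4000 nM to 50000 nM. The expected step is thus a 4.1-fold lower number from compound 2 to compound 4 (0.61 log units; beyond the scatter).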

Compound 4, concentration for total growth inhibition: 83200 nM
Compound 4: the middle estimate sits 5.5-fold (0.74 log units) below what was measured; measured number above the stated range.
By their numbers in this assay, from the lowest: compounds 3 and 1 (each within the scatter of the next); then compounds 2 and 4 (each within the scatter of the next).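

In this assay, amino and hydrogen on this aromatic carbon, between two ring nitrogen atoms, cannot be told apart (a 1.3-fold higher number from compound 2 to compound 4 (0.13 log units; within the scatter)). Chloro at the same carbon does stand apart from amino (a 15-fold higher number from compound 1 to compound 4 (1.18 log units; beyond the scatter)), so a nitrogen substituent as small as amino does not reproduce what chloro gives on this core. On these data alone, whether methoxy, a dimethylamino group or a longer chain at this carbon falls with chloro or with hydrogen and amino remains open. Nothing shown here explains why chloro stands apart from the other two groups.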